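From Acetyl to Methyl on an Inactive Compound

This account rests on a few compounds, and the source may have more. Where it says the series, first, only, none or still open, it means among the compounds named here.

So far, three compounds sharing one core have been tested in a functional assay on HL-60 cells (Homo sapiens) for inhibition, read by MTT assay, with a stated time of 72 h; a lower number here means a stronger inhibitor, a higher number a weaker inhibitor. Compound 1 `Cc1nc(-c2ccccc2)c(C(=O)N2CCN(c3cccc(Cl)c3Cl)CC2)o1` gives 133 nM and compound 2 `Cc1nc(-c2ccccc2)c(C(=O)N2CCN(c3cccc(C(N)=O)c3)CC2)o1` gives 71 nM, while compound 3 `CC(=O)c1ccc(N2CCN(C(=O)c3oc(C)nc3-c3ccccc3)CC2)cc1` stands apart, reported only as "not active" (no number reported). So compound 3 offers no number from which to measure a step.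

The next compound, compound 4 `Cc1ccc(N2CCN(C(=O)c3oc(C)nc3-c3ccccc3)CC2)cc1`, differs from compound 3 in one place. It has methyl in place of acetyl on an aromatic carbon, para to a large group, so 4-acetylphenyl becomes 4-methylphenyl (methyl in place of acetyl on an aromatic carbon).

Within the data shown here, no measured step covers this exact swap. The closest evidence is a 1.9-fold lower number from compound 1 to compound 2 (0.27 log units; within the scatter), which also exchanges groups on the phenyl and stays within the scatter. That makes a number close to those of the two measured compounds a reasonable expectation, and any number would be a move away from the result for compound 3. The size of that move cannot be stated, and compound 4 may also give no number, as compound 3 did with "not active" (no number reported). The expected value for compound 4 is therefore a weaker one than those measured, estimated at 200 nM, within a wide expected range of 40 nM to 2000 nM.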

Compound 4, half-maximal inhibitory concentration: > 1000 nM
Compound 4: only a limit was reported; the forecaster's own chance of this, stated with the estimate: 30%; middle value at least 5.0-fold (0.69 log units) away from the limit.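

In this assay compound 4 gives > 1000 nM, which is a limit of the assay and not a number: the limit of > 1000 nM in this assay, at which 1 of the 4 values shown sits.

Even so, the limit shows that the group on the phenyl ring can matter in this series. Among these compounds, the change to 4-methylphenyl gives an at least 14-fold higher number from compound 2 to compound 4 (1.14 log units; beyond the scatter) and an at least 7.5-fold higher number from compound 1 to compound 4 (0.87 log units; beyond the scatter), both beyond the scatter, whereas the one earlier step, a 1.9-fold lower number from compound 1 to compound 2 (0.27 log units; within the scatter), stayed within it. Compound 3 and compound 4 each carry their group para to a large group, and neither gives a number, so replacing acetyl with methyl at this position yields no measured value and the step between them cannot be read.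

The compounds shown hold no pair with the same group at two different places on the phenyl ring, so it remains open whether the position or the group itself decides the outcome. On these data alone, it also remains open how an amine or a carboxylic acid para to a large group would read in this assay.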